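The compounds below may be only part of what the source reports. "The series", "measured", "known", "first", "only" and "open" are said of these compounds alone.

Compound 1 `COc1cc(OC)c2sc(-c3ccc(N/C=C\C(=O)c4ccc(OC)c([N+](=O)[O-])c4)c(C)c3)nc2c1`: 10800 nM
Compound 2 `COc1cc(OC)c2sc(-c3ccc(N/C=C\C(=O)c4cc(OC)c(OC)c([N+](=O)[O-])c4)cc3)nc2c1`: 3060 nM
Compound 3 `COc1cc(OC)c2sc(-c3ccc(N/C=C\C(=O)c4cc(OC)c(OC)c(OC)c4)c(C)c3)nc2c1`: 13800 nM

These three compounds share one core and differ only in the ring attached to the carbonyl carbon and in whether a methyl sits on the ring bearing the nitrogen. In a functional assay on MDA-MB-231 cells (Homo sapiens) for antiproliferative activity, read by sulforhodamine B assay, with a stated time of 48 h (on this read-out lower numbers stand for stronger inhibition and higher numbers for weaker inhibition), compound 3 gives the highest of the three numbers; compound 1 stands nearest to it, within the scatter, while compound 2 lies furthest, beyond the scatter, with a clearly lower number.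

Compound 4 `COc1cc(OC)c2sc(-c3ccc(N/C=C\C(=O)c4cc(OC)c(OC)c([N+](=O)[O-])c4)c(C)c3)nc2c1` has not yet been measured. It differs from compound 3 in one place: nitro in place of methoxy on an aromatic carbon. Among the compounds with values here, only one measured step bears on a nitro-for-methoxy exchange on this ring: a 1.3-fold higher number from compound 1 to compound 3 (0.11 log units; within the scatter), where 3,4,5-trimethoxyphenyl took the place of 4-methoxy-3-nitrophenyl on the carbonyl carbon, and the number did not move beyond the scatter. Within the data shown here, compound 2 carries the same nitro and methoxy pattern as compound 4 but lacks the methyl, and its value is well below that of compound 3; no single-change step links those two compounds, so this is only a hint.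

Compound 4 is therefore expected to give 7000 nM in this assay, within 2500 nM to 20000 nM. The step this implies, a 2.0-fold lower number from compound 3 to compound 4 (0.29 log units; within the scatter), is an estimate of a modest move toward a lower number.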

Compound 4, half-maximal inhibitory concentration: 7400 nM
Estimate against measurement, compound 4: 1.1-fold (0.02 log units) below; measured number inside the range.
By their numbers in this assay, from the lowest: compound 2; then compounds 4, 1 and 3 (each within the scatter of the next).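

In this assay, the nitro-for-methoxy exchange on this ring now has a direct reading with the third methoxy group kept in place (a 1.9-fold lower number from compound 3 to compound 4 (0.27 log units; within the scatter)), and it stays within the scatter, as the earlier step between the two ring patterns did. Adding a methoxy group to the nitro-bearing ring with the methyl present also stays within the scatter (a 1.5-fold lower number from compound 1 to compound 4 (0.16 log units; within the scatter)), so compounds 1, 3 and 4 give no sign that these ring changes matter in this assay. Within the data shown here, the one new step beyond the scatter is a modest one and belongs to the methyl, not to the nitro (a 2.4-fold higher number from compound 2 to compound 4 (0.38 log units; beyond the scatter)), which shows that the low number of compound 2 goes with the absence of the methyl in this pair. No measurement shown here accounts for any of these steps.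

From the compounds shown here alone, the methyl step rests on this single pair, so it remains open whether it holds with the other ring patterns, or whether a longer chain such as ethyl would go the same way. Also open, going by these compounds, is whether an amine or a carboxylic acid in place of the nitro would move the number beyond the scatter.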